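Amide aryl swap on the shared core

A few compounds are considered here, and "the series" means these few. Any claim that something is new, unique, unknown or untested is made for them only; others in the source may bear on it.

Compound 1 `O=C(COc1ccc2cc(/C=C3/SC(=O)NC3=O)ccc2c1)Nc1cccc(F)n1` carries a 6-fluoropyridin-2-yl on the amide-type nitrogen. Going by the values given here, in an assay on isolated protein for inhibition of histone deacetylase 8 (Homo sapiens), with a stated time of 1 h (a higher number here means a weaker inhibitor, a lower number a stronger inhibitor), compound 1 gives 7200 nM, the only numeric value in the set. Compound 2 `O=C(COc1ccc2cc(/C=C3/SC(=O)NC3=O)ccc2c1)Nc1cccc(C(F)(F)F)c1` bears 3-(trifluoromethyl)phenyl on that nitrogen. In this assay compound 2 reaches only > 50000 nM, which is a limit of the assay and not a number. Among the compounds with values here, the step of an at least 6.9-fold higher number from compound 1 to compound 2 (0.84 log units; beyond the scatter) is the single measured step away from compound 1, and it ends at the limit of > 50000 nM in this assay, at which 1 of the 2 values shown sits. Compound 3 `O=C(COc1ccc2cc(/C=C3/SC(=O)NC3=O)ccc2c1)Nc1c(F)cc(F)cc1Br` differs from compound 1 by 2-bromo-4,6-difluorophenyl in place of 6-fluoropyridin-2-yl on an amide-type nitrogen. Here too a six-membered aromatic ring of carbon only replaces the 6-fluoropyridin-2-yl on the amide-type nitrogen, and the one step that bears on this change points toward a weaker inhibitor, so a step of comparable size in that direction is expected in this assay. Compound 3 is therefore estimated at 30000 nM (range 8000 nM to 80000 nM), a step of a 4.2-fold higher number from compound 1 to compound 3 (0.62 log units; beyond the scatter), with a fair chance that only a limit is returned.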

Compound 3, half-maximal inhibitory concentration: > 50000 nM
Compound 3 ended at the assay's limit; the forecaster's own chance of this, stated with the estimate: 50%; middle value at least 1.6-fold (0.22 log units) from the limit.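

In this assay, the swap to 2-bromo-4,6-difluorophenyl gives an at least 6.9-fold higher number from compound 1 to compound 3 (0.84 log units; beyond the scatter), a second case of a ring of carbon only costing activity on the amide-type nitrogen, here with a different set of substituents on that ring. Compound 2 and compound 3 both return only a limit of the assay and not a number, so the step between them cannot be read: the limit of > 50000 nM in this assay, at which 2 of the 3 values shown sit.

Among the three compounds, only compound 1 has a ring hetero atom on this nitrogen and only compound 1 gives a number, though ring nitrogen and substituents change together in both steps, so neither is singled out. Open, as far as these compounds go, is whether plain phenyl, or a pyridin-2-yl with an amine in place of the fluorine, would match compound 1 at 7200 nM.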